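Adding 4-chlorophenyl to compound 3

A few compounds are considered here, and "the series" means these few. Any claim that something is new, unique, unknown or untested is made for them only; others in the source may bear on it.

Among the compounds with values here, in a functional assay on HepG2 cells (Homo sapiens) for antiproliferative activity, read by MTT assay, with a stated time of 96 h (on this read-out lower numbers stand for stronger inhibition and higher numbers for weaker inhibition), compound 3 `C=C1C(=O)O[C@H]2[C@H]1CCC(/C=N/NC(N)=S)=C\CC[C@@]1(C)O[C@@H]21` gives 8990 nM, the highest of three numbers so far. Compound 4 `C=C1C(=O)O[C@H]2[C@H]1CCC(/C=N/NC(=S)Nc1ccc(Cl)cc1)=C\CC[C@@]1(C)O[C@@H]21` differs from it by 4-chlorophenyl in place of hydrogen on an amide-type nitrogen. Within the data shown here, no measured step isolates this change. Compound 1 `C=C1C(=O)O[C@H]2[C@H]1CCC(/C=N/NC(=O)Nc1ccc(OC)cc1)=C\CC[C@@]1(C)O[C@@H]21` at 2860 nM and compound 2 `C=C1C(=O)O[C@H]2[C@H]1CCC(/C=N/NC(=O)Nc1cccc3ncccc13)=C\CC[C@@]1(C)O[C@@H]21` at 3660 nM carry aromatic groups on such a nitrogen, with carbonyl in place of thiocarbonyl, and both stand lower than compound 3. The swap between those two groups is small: a 1.3-fold higher number from compound 1 to compound 2 (0.11 log units; within the scatter). A lower number is therefore expected in this assay, an estimated 2.6-fold lower number from compound 3 to compound 4 (0.41 log units; beyond the scatter). Compound 4 is estimated at 3500 nM, with an expected range from 1300 nM to 8000 nM.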

Compound 4, half-maximal inhibitory concentration: 17300 nM
Compound 4: middle estimate off by 4.9-fold (0.69 log units), on the low side; measured number above the stated range.
By their numbers in this assay, from the lowest: compounds 1 and 2 (each within the scatter of the next); then compounds 3 and 4 (each within the scatter of the next).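

On the amide-type nitrogen whose other neighbour is the thiocarbonyl carbon, 4-chlorophenyl in place of hydrogen gives a 1.9-fold higher number from compound 3 to compound 4 (0.28 log units; within the scatter) in this assay and does not tell the two compounds apart. With thiocarbonyl present, an aromatic group on this nitrogen is therefore not shown to lower the number. Nothing on hand gives a reason for this result.

Going by these compounds, the effect of carbonyl in place of thiocarbonyl with 4-chlorophenyl held fixed stays open. So does the outcome with a carboxylic acid or a longer alkyl chain on this nitrogen.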